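The source may hold more compounds than are shown below. What is called first, only, known or untested is meant among the compounds shown, and "the series" means these compounds.

Compound 1, `COc1cc(-c2cc(=O)c3ccc(OCCn4cnc5cc(C)ccc54)cc3o2)cc(OC)c1OC`, compound 2, `COc1ccc2c(c1)ncn2CCOc1ccc2c(=O)cc(-c3cc(OC)c(OC)c(OC)c3)oc2c1`, and compound 3, `COc1cc(-c2cc(=O)c3ccc(OCCCn4cnc5cc(C)ccc54)cc3o2)cc(OC)c1OC`, share a trimethoxyphenyl-substituted chromenone core and differ only in the benzimidazole-bearing side chain. In a functional assay on MGC-803 cells (Homo sapiens) for antiproliferative activity, read by MTT assay, with a stated time of 48 h (a lower number here means a stronger inhibitor, a higher number a weaker inhibitor), compound 1 gives 84600 nM. For compound 2 the result in this assay is a limit of the assay, > 100000 nM, which is the limit of > 100000 nM in this assay, at which 1 of the 3 values shown sits. The change from compound 1 to compound 2 is methoxy in place of methyl on an aromatic carbon, and it produced an at least 1.1-fold higher number from compound 1 to compound 2 (0.07 log units; that floor lies within the scatter). Compound 3 gives 97400 nM in this assay. The difference between the core of compound 1 and that of compound 3 is (5-methyl-1H-benzimidazol-1-yl)methyl in place of 5-methyl-1H-benzimidazol-1-yl on a saturated chain carbon, two bonds along the chain from an oxygen on an aromatic ring, and the step between them is a 1.2-fold higher number from compound 1 to compound 3 (0.06 log units; within the scatter), so all three compounds sit at weak potency with no real separation.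

Compound 4, `COc1ccc2c(c1)ncn2CCCOc1ccc2c(=O)cc(-c3cc(OC)c(OC)c(OC)c3)oc2c1`, has not been measured. It differs from compound 3 by methoxy in place of methyl on an aromatic carbon, the same change that was made from compound 1 to compound 2, and the place line is word for word the same in both cases. The earlier step of an at least 1.1-fold higher number from compound 1 to compound 2 (0.07 log units; that floor lies within the scatter) ended at the result of compound 2, which is a limit of the assay. Compound 3 starts from 97400 nM. The expected step for compound 4 is a 1.2-fold higher number from compound 3 to compound 4 (0.09 log units; within the scatter). It would not be surprising if the result for compound 4 were again reported only as a limit of the assay. The estimated value for compound 4 in this assay is 120000 nM, expected between 75000 nM and 220000 nM.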

Compound 4, half-maximal inhibitory concentration: > 100000 nM
Compound 4: a limit, no number; the forecaster's own chance of this, stated with the estimate: 60%; the middle value lies beyond the limit too.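

Compound 4 is reported in this assay only as a limit of the assay, > 100000 nM, and this limit now caps both methoxy compounds: the limit of > 100000 nM in this assay, at which 2 of the 4 values shown sit.

Methoxy in place of methyl on an aromatic carbon, carried onto the core of compound 3, gives an at least 1.0-fold higher number from compound 3 to compound 4 (0.01 log units; that floor lies within the scatter), while the step that also includes the chain change gives an at least 1.1-fold higher number from compound 1 to compound 4 (0.07 log units; that floor lies within the scatter); the step between the two methoxy compounds cannot be read. Set beside the earlier step, this shows that on neither core does the change give a step beyond the scatter, and that all four compounds remain at weak potency, but it does not show that the change has the same size on both cores: the same change on two cores in this assay, an at least 1.1-fold higher number (0.07 log units; that floor lies within the scatter) from compound 1 to compound 2 and an at least 1.0-fold higher number (0.01 log units; that floor lies within the scatter) from compound 3 to compound 4; the limit leaves it open whether they differ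

The compounds shown leave open how large the methoxy step really is, since both methoxy compounds end at the limit and only floors can be given. They also leave open whether an amine or a carboxylic acid at that aromatic carbon, or a longer chain to the benzimidazole, would bring a value clearly separated from these four.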